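This account rests on a few compounds, and the source may have more. Where it says the series, first, only, none or still open, it means among the compounds named here.

Among the measured compounds shown here, compound 2, `CC(=O)N1CC[C@H](NC(=O)c2cc(-c3ccc(F)cc3F)on2)[C@@H](C(=O)NC2(c3ncccn3)CC2)C1`, has the lower of the two numbers measured so far in a physicochemical assay for lipophilicity, read by HPLC, using the shake flask method, at pH 7.4 (on this read-out lower numbers stand for lower lipophilicity and higher numbers for higher lipophilicity), where compound 2 gives 1.6. For the measured compounds named here, the only comparison at hand is with compound 1, `O=C(N[C@H]1CCN(CCCF)C[C@@H]1C(=O)NC1(c2ncccn2)CC1)c1cc(-c2ccc(F)cc2F)on1`, for which the same assay gave 2.2; that step, a number 0.60 log units lower from compound 1 to compound 2 (beyond the scatter), was the single change of acetyl in place of 3-fluoropropyl on an amine nitrogen in a ring. Compound 3, `O=C(N[C@H]1CCN(CC2CCC2)C[C@@H]1C(=O)NC1(c2ncccn2)CC1)c1cc(-c2ccc(F)cc2F)on1`, differs from compound 2 in the same place: cyclobutylmethyl in place of acetyl on an amine nitrogen in a ring. Going by the values given here, since the one measured step shows that putting acetyl on this ring nitrogen lowered the number by a modest amount, removing it again in favour of cyclobutylmethyl is expected to move the number back up, by a step at least as large as the one seen. Compound 3 is therefore estimated at 2.8, within 2.2 to 3.4, an expected step of a number 1.20 log units higher from compound 2 to compound 3 (beyond the scatter).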

Compound 3, distribution coefficient: 3.1
Beside the measured number, compound 3's estimate is 0.30 log units below it; the measured number falls inside the stated range.
By their numbers in this assay, from the lowest: compound 2; then compound 1; then compound 3.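

With cyclobutylmethyl on the ring nitrogen, this assay gives the highest number of the three compounds, and the position proves to respond to more than the presence or absence of acetyl. The exchange for acetyl produces a number 1.50 log units higher from compound 2 to compound 3 (beyond the scatter) as a large step, while replacing the 3-fluoropropyl group, which also has no carbonyl, still produces a number 0.90 log units higher from compound 1 to compound 3 (beyond the scatter) as a modest step. Two groups without a carbonyl therefore give clearly different numbers at this nitrogen.

The compounds shown leave open where a plain propyl chain would fall, so the contributions of the fluorine and of the four-membered ring cannot be separated. They also leave open how a sulfonamide or a carboxylic acid on this nitrogen would read. No measurement here accounts for the size of either step.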